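Tail flick notes: branched alkyl in place of guanidine chain

The source may hold more compounds than are shown below. What is called first, only, known or untested is meant among the compounds shown, and "the series" means these compounds.

Measured so far:
compound 1 `N=C(N)NCCC[C@H](NC(=O)CN(c1nc(Cl)nc2[nH]cnc12)C1CC1)C(=O)OCc1ccccc1` — 10.2%
compound 2 `CC(C)[C@H](NC(=O)CN(c1ncnc2c1ncn2C1CCCCO1)C1CC1)C(=O)OCc1ccccc1` — 25.8%
compound 3 `CC[C@H](C)[C@H](NC(=O)CN(c1ncnc2c1ncn2C1CCCCO1)C1CC1)C(=O)OCc1ccccc1` — 20.4%

In a functional assay on the whole organism (Tail, strain ICR) with Mus musculus as the target, in the tail flick test, with a stated time of 120 min, at a dose of 25 umol/kg by the oral route (a higher number here means a stronger effect of the compound at the dose given, a lower number a weaker effect), compound 1 gives 10.2%, the lowest of the three numbers; compound 3 stands higher by a gap beyond the scatter, and compound 2 further still. Going by the values given here, the only step between measured compounds, a number 5.4 percentage points lower from compound 2 to compound 3 (within the scatter), is a small alkyl change that lies within the scatter and so carries no direction of its own.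

Compound 4 `CC(C)C[C@H](NC(=O)CN(c1nc(Cl)nc2[nH]cnc12)C1CC1)C(=O)OCc1ccccc1` is not yet measured. It differs from compound 1 by a group of 3 heavy atoms (3 carbon; no ring) in place of a group of 6 heavy atoms (3 carbon, 3 nitrogen; no ring), on a saturated chain carbon, two bonds along the chain from an amide-type nitrogen and a carbonyl carbon. Among the compounds with values here, no measured step covers this change: compounds 2 and 3 carry branched alkyl side chains but a different core, so their higher values in this assay are only a loose pointer. Given that compound 1 sits at 10.2% while compounds 2 and 3 with branched alkyl chains sit higher, compound 4 is expected to move upward, with the step of a number 9.8 percentage points higher from compound 1 to compound 4 (within the scatter) estimated as modest and uncertain. The estimate for compound 4 is 20%, in the range 5% to 35%.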

Compound 4, a percentage reported as activity, at one dose (the size of the read-out at that dose, not a potency): 8.58%
Compound 4: middle estimate off by 11.4 percentage points, on the high side, within the range that was stated.
By their numbers in this assay, from the lowest: compounds 4 and 1 (each within the scatter of the next); then compounds 3 and 2 (each within the scatter of the next).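

In this assay, isopropyl in place of the group of 6 heavy atoms (3 carbon, 3 nitrogen), on a saturated chain carbon, two bonds along the chain from an amide-type nitrogen and a carbonyl carbon, reads as a number 1.6 percentage points lower from compound 1 to compound 4 (within the scatter). On this core, then, removing the 3 hydrogen-bond donors of the leaving group from this position leaves the number within the scatter at this single dose and time. Nothing shown bears on why the two compounds read alike.

From the compounds shown here alone, whether an amine, a carboxylic acid or a longer chain at this position would give a different number on this core remains open. Going by these compounds, compounds 2 and 3 differ from compound 4 in more than one place, so the part played by the core in their numbers also remains open.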